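Amide carbonyl substituent variation in a GIPR series

A few compounds are considered here, and "the series" means these few. Any claim that something is new, unique, unknown or untested is made for them only; others in the source may bear on it.

Among the compounds with values here, compound 2 `Cc1nc(S(C)(=O)=O)ccc1Oc1ncnc(OC2CCN(C(=O)C(C)(F)F)CC2)c1F` gives 87% in a functional assay on isolated protein for inhibition of Glucose-dependent insulinotropic receptor (Rattus norvegicus), read by HTRF and cAMP accumulation (a lower number here means a smaller maximal response, a higher number a larger maximal response), the higher of the two numbers so far; compound 1 `Cc1nc(S(C)(=O)=O)ccc1Oc1ncnc(OC2CCN(C(=O)OC(C)C)CC2)c1F` gives 77%, and the two lie within the scatter of each other. Compound 3 `CCc1cnc(C(=O)N2CCC(Oc3ncnc(Oc4ccc(S(C)(=O)=O)nc4C)c3F)CC2)nc1` carries the change (5-ethylpyrimidin-2-yl in place of 1,1-difluoroethyl on a carbonyl carbon). Within the data shown here, the only measured step at this carbonyl carbon, a number 10 percentage points higher from compound 1 to compound 2 (within the scatter), stayed within the scatter, so no step beyond the scatter is expected here either, in either direction. Compound 3 is therefore expected to give about 84%, within a range of 66% to 100%, which would mean an estimated step of a number 3 percentage points lower from compound 2 to compound 3 (within the scatter).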

Compound 3, largest response reached (reported as efficacy), in percent of the reference or control that the assay uses: 80%
Compound 3: middle estimate off by 4 percentage points, on the high side, within the range that was stated.
By their numbers in this assay, from the lowest: compounds 1, 3 and 2 (each within the scatter of the next).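

In this assay, an aromatic ring on this carbonyl carbon gives a number 7 percentage points lower from compound 2 to compound 3 (within the scatter), and a number 3 percentage points higher from compound 1 to compound 3 (within the scatter). The 5-ethylpyrimidin-2-yl group, much larger than 1,1-difluoroethyl at 8 heavy atoms against 4, therefore stands level with both earlier groups, and no order among the three can be read at this position. Nothing available bears on a cause for these results. Still open, as far as these compounds go, is whether any group on this carbonyl carbon produces a step beyond the scatter, for example a phenyl ring, a primary amine or a longer alkyl chain.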